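The source may report more compounds than this note shows. Statements on the series, on what has been measured and on what is new or still open speak of the compounds shown alone.

Compound 1 `COc1ccc(-c2sc(C(=O)O)cc2-c2cc(OC)c(OC)c(OC)c2)cc1O` carries a carboxy group on its five-membered ring and gives 7510 nM in a functional assay on HT-1080 cells (Homo sapiens) for antiproliferative activity, read by MTT assay, with a stated time of 72 h; on this read-out lower numbers stand for stronger inhibition and higher numbers for weaker inhibition. Compound 2 `COc1ccc(-c2sccc2-c2cc(OC)c(OC)c(OC)c2)cc1O` keeps the same core but has hydrogen in place of carboxy on an aromatic carbon; in this assay compound 2 gives 1940 nM, and the step of a 3.9-fold lower number from compound 1 to compound 2 (0.59 log units; beyond the scatter) lies beyond the usual scatter. Compound 3 `COc1ccc(-c2cc(C(=O)O)sc2-c2cc(OC)c(OC)c(OC)c2)cc1` rests on a different core, the difference between the two cores is not broken down here; in this assay compound 3 gives 5810 nM, a number within the scatter of compound 1 and well above that of compound 2. Compound 4 `COc1ccc(-c2ccsc2-c2cc(OC)c(OC)c(OC)c2)cc1` is obtained from compound 3 by hydrogen in place of carboxy on an aromatic carbon. This is the same kind of change as from compound 1 to compound 2, though the surroundings differ: in compound 3 the ring atom two bonds away bears a 4-methoxyphenyl group, where compound 1 bears a 3-hydroxy-4-methoxyphenyl group. Because of a 3.9-fold lower number from compound 1 to compound 2 (0.59 log units; beyond the scatter) the step of a 3.9-fold lower number from compound 3 to compound 4 (0.59 log units; beyond the scatter) is expected to be of a similar size. Compound 4 is therefore estimated to give 1500 nM, within 600 nM to 4000 nM, in this assay.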

Compound 4, half-maximal inhibitory concentration: 3620 nM
Estimate against measurement, compound 4: 2.4-fold (0.38 log units) below, within the range that was stated.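

In this assay, hydrogen in place of carboxy gives a 1.6-fold lower number from compound 3 to compound 4 (0.21 log units; within the scatter), so on this core the change cannot be told apart from repeat-measurement noise, although the same change went beyond the scatter on the core of compound 1. Set side by side, the two steps do not differ by more than two such measurements allow: the same change on two cores in this assay, a 3.9-fold lower number (0.59 log units; beyond the scatter) from compound 1 to compound 2 and a 1.6-fold lower number (0.21 log units; within the scatter) from compound 3 to compound 4, 2.4-fold (0.38 log units) apart, within the scatter of two such steps. This shows that the two results are compatible with one step size on both cores, but with a single pair on each core it neither proves that the size is the same nor shows how far the change would carry to any other core in this series.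

The compounds shown leave open what another group in the place of the carboxy group, such as a methyl ester, an amide or an amine, would do to the number in this assay. They also leave open what the 3-hydroxy-4-methoxyphenyl group and the 4-methoxyphenyl group contribute on their own, as no pair shown differs in that group alone.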